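Removing a methyl from an inactive sulfone pyrazole

A few compounds are considered here, and "the series" means these few. Any claim that something is new, unique, unknown or untested is made for them only; others in the source may bear on it.

The compounds share a core in which a sulfone links a pyrazole to a five-membered ring that carries a nitrogen. Compound 1 `O=S(=O)(CC1=NCCO1)c1n[nH]cc1-c1ccccc1` carries an oxygen in that ring and a plain phenyl on the pyrazole. In a functional assay, tested at 75 ug/mL (on this read-out higher numbers stand for a stronger effect at the one concentration tested and lower numbers for a weaker effect), compound 1 gives 55.6%. Compound 2 `O=S(=O)(CC1=NCCS1)c1n[nH]cc1-c1ccc(Cl)cc1` has sulfur in the ring and a chlorine on the phenyl; in this assay compound 2 was reported as "not active" (no number reported). Compound 3 `Cc1ccc(-c2c[nH]nc2S(=O)(=O)CC2=NCCS2)cc1` keeps the sulfur and bears a methyl on the phenyl; in this assay compound 3 was likewise reported as "not active" (no number reported), so no single number is known for it, and compound 2 is the one further entry without a number.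

Compound 4 `O=S(=O)(CC1=NCCS1)c1n[nH]cc1-c1ccccc1` differs from compound 3 in one place: hydrogen in place of methyl on an aromatic carbon. Hydrogen in place of methyl on an aromatic carbon gives a phenyl that matches compound 1, while the sulfur ring matches compounds 2 and 3. Within the data shown here, no measured step covers this change, so its size in this assay cannot be read from the data; a gain from the inactive level is plausible but uncertain. Compound 4 is expected to give about 30%, estimated to fall between 0% and 60%.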

Compound 4, a percentage reported as activity, at one concentration (the size of the read-out at that concentration, not a potency): "not active" (no number reported)
No number was reported for compound 4, so the estimate cannot be set against anything.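

Compound 3 and compound 4 are both reported as not active in this assay without a number, so no step can be read between them. No measured evidence offers an explanation for this result.

From the compounds shown here alone, whether the change from 4-methylphenyl to phenyl affects this assay at all remains open.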